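The compounds below may be only part of what the source reports. "The series", "measured", "known", "first", "only" and "open" are said of these compounds alone.

Of the compounds shown here, three have been measured for growth inhibition of a kidney-derived tumour cell line. Compound 1, `O=C(/C=C/c1ccc(O)cc1)c1c(O)cccc1OCCC1CCCC1`, gives 3400 nM in a functional assay on ACHN cells (Homo sapiens) for antiproliferative activity, read by sulforhodamine B assay; a lower number here means a stronger inhibitor of growth, a higher number a weaker inhibitor of growth. Among the measured compounds shown here, compound 3, `CC(C)(C)CCOc1cccc(O)c1C(=O)/C=C/c1ccc(S(N)(=O)=O)cc1`, gives 3300 nM in this assay, a value that sits within the scatter of the one for compound 1, so the two cannot be ordered. Compound 2, `CC(C)(C)CCOc1cccc(O)c1C(=O)CCc1ccc(O)cc1`, reaches only a limit in this assay, > 30000 nM; this is the limit of > 30000 nM in this assay, at which 1 of the 3 values shown sits, and it is one of the three values shown. Of the two compounds that yield numbers, compound 1 therefore stands at the higher one, though the gap to compound 3 is not one that the assay can resolve.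

Compound 4, `CC(C)COc1cccc(O)c1C(=O)/C=C/c1ccc(O)cc1`, has not yet been measured in this assay. It differs from compound 1 in a single place: isopropyl in place of cyclopentylmethyl on a saturated chain carbon bound to an oxygen on an aromatic ring. The cyclopentylmethyl group gives way to the smaller isopropyl group on the saturated chain carbon bound to the oxygen on the aromatic ring, and the rest of the shared core is untouched. For the measured compounds named here, no measured pair in the set isolates this change, so any expectation rests on the magnitude of the shortening alone. The author expects a moderate loss, a step of a 2.1-fold higher number from compound 1 to compound 4 (0.31 log units; beyond the scatter), somewhat beyond the scatter of this assay but not large. Compound 4 is thus estimated at 7000 nM, with a range from 2500 nM to 20000 nM.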

Compound 4, concentration for 50% growth inhibition: 3290 nM
Compound 4: the middle estimate sits 2.1-fold (0.33 log units) above what was measured, within the range that was stated.
By their numbers in this assay, from the lowest: compounds 4, 3 and 1 (each within the scatter of the next). At a limit, above all of these: compound 2.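

In this assay, among the compounds shown here, replacing cyclopentylmethyl with isopropyl on a saturated chain carbon bound to an oxygen on an aromatic ring gives a 1.0-fold lower number from compound 1 to compound 4 (0.01 log units; within the scatter), the first step in this set that isolates a change at this position. Across this pair, the group can lose its five-membered non-aromatic ring of carbon only and go from 6 heavy atoms to 3 with no difference that this assay can resolve, so neither the ring nor the larger size of cyclopentylmethyl is needed to keep the number where it stands for this pair. The data shown offer no explanation for this result.

On these data alone, both groups in this pair are made of carbon only, so it remains open whether this position would accept an amine, a carboxylic acid or a much longer chain in the same way. Also open, as far as these compounds go, is whether isopropyl in place of cyclopentylmethyl would give the same result on a compound whose other end carries the sulfonamide of compound 3, or the saturated link of compound 2.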